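The source may report more compounds than this note shows. Statements on the series, on what has been measured and on what is new or still open speak of the compounds shown alone.

Measured so far in an ADME assay on U2OS cells (Homo sapiens) for cytotoxicity, with a stated time of 96 h; on this read-out higher numbers stand for lower toxicity in this test and lower numbers for higher toxicity in this test:

- compound 1, `Cn1c(SCC(=O)N2CCN(c3ccccc3F)CC2)nnc1-c1cccnc1`: 198000 nM
- compound 2, `CC(C)COc1ccc(CN(Cc2ccncc2)S(=O)(=O)c2cccc(F)c2)cc1`: a limit, > 200000 nM

Compound 1 gives a numerical result in this assay, 198000 nM. Compound 2 does not give a number in this assay, only a limit, > 200000 nM; its place is therefore known only from the limit of > 200000 nM in this assay, at which 1 of the 2 values shown sits. Going by the values given here, no two measured compounds differ in a single place, so no measured step is available, and the two values shown lie close to one another on the scale of the read-out.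

Compound 3 `CC(C)COc1ccc(CN(Cc2ccncc2)S(=O)(=O)c2ccc(F)c(F)c2)cc1` is the next compound for this assay. Compared with compound 2, it carries fluoro in place of hydrogen on an aromatic carbon, the whole aryl group reading 3-fluorophenyl to 3,4-difluorophenyl. Among the compounds with values here, the change is a single small substituent without donors, acceptors or charge, and nothing among the measured compounds points to a shift in either direction.

The expectation for this assay is therefore a step of a number no higher from compound 2 to compound 3 (the limit leaves the size open), within the scatter. Compound 3 is estimated at 200000 nM, between 100000 nM and 400000 nM, with a good chance that it again comes back only as a limit.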

Compound 3, half-maximal cytotoxic concentration: 11500 nM
Estimate against measurement, compound 3: 17-fold (1.24 log units) above, and the stated range ends above it.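

In this assay, the aromatic carbon ortho to a fluoro group and para to a large group is not a silent place in this series: fluoro in place of hydrogen, reading 3-fluorophenyl to 3,4-difluorophenyl, gives an at least 17-fold lower number from compound 2 to compound 3 (1.24 log units; beyond the scatter). Going by these compounds alone, this is the first single-place step, and it shows that one added heavy atom, with no hydrogen-bond donors, no hydrogen-bond acceptors and no net charge, can move the read-out beyond the scatter towards higher toxicity in this test. Compound 2 stands only as a limit, so the size of the step is fixed on one side and open on the other: the limit of > 200000 nM in this assay, at which 1 of the 3 values shown sits.

On these data alone, whether the shift belongs to fluoro itself or would follow any substituent on this carbon remains open, and a chloro, a methoxy or an amine at the same place would separate these readings. Also open, as far as these compounds go, is whether the same change would act alike on the core of compound 1, or whether it depends on the 3-fluoro group already present in compound 2.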